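Cytotoxicity notes on a phenoxyhexyl imidazolidinone series

The source may hold more compounds than are shown below. What is called first, only, known or untested is meant among the compounds shown, and "the series" means these compounds.

Compound 1 `O=C1N(CCCCCCOc2ccc(Cl)cc2)CCN1c1ccncc1` reaches only the assay limit of > 25000 nM in a functional assay on cells (Homo sapiens) for cytotoxicity; a lower number here means that less compound is tolerated, a higher number that more compound is tolerated.
Compound 2 `O=C1N(CCCCCCOc2cccc3cccnc23)CCN1c1ccncc1` likewise gives only the limit > 25000 nM in this assay.
Compound 3 `O=C1N(CCCCCCOc2ccc(Cl)cc2)CCN1c1cccnc1` also gives only the limit > 25000 nM in this assay.

For the measured compounds named here, compound 3 thus stands at the limit together with the other two; no number separates them, and the single one-change step, a step that the two limits leave unreadable from compound 1 to compound 3, cannot be read because of the limit of > 25000 nM in this assay, at which 3 of the 3 values shown sit. Compound 4 `O=C1N(CCCCCCOc2ccc(Br)cc2)CCN1c1cccnc1` differs from compound 3 by bromo in place of chloro on an aromatic carbon. Going by the values given here, no measured step addresses this change, and the series offers no evidence of any compound falling below the limit. For compound 4 the expected step that the limit leaves unreadable from compound 3 to compound 4 is none beyond the scatter. Compound 4 is therefore estimated at 30000 nM, within 20000 nM to 60000 nM, most likely again reported only as a limit.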

Compound 4, half-maximal cytotoxic concentration: > 25000 nM
Compound 4 was reported as a limit (the forecaster's own chance of this, stated with the estimate: 85%); the middle value is on the limit's open side.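

Compound 4 sits at the same limit as compound 3, so bromo in place of chloro gives no readable step: the limit of > 25000 nM in this assay, at which 4 of the 4 values shown sit.
The compounds shown leave open at what concentration any of them turns cytotoxic, and which structural change would shift that.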